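Cytotoxicity notes: piperazinyl in place of the aminopropyl chain

This account rests on a few compounds, and the source may have more. Where it says the series, first, only, none or still open, it means among the compounds named here.

Compound 1 `CN(C)CCCNc1nc2cc([N+](=O)[O-])ccc2nc1NCc1ccc(C(F)(F)F)cc1` gives 5.66 ug/mL in an ADME assay on HEK293 cells (Homo sapiens) for cytotoxicity, read by MTT assay, with a stated time of 24 h; a lower number here means a stronger inhibitor, a higher number a weaker inhibitor. It stands lowest of the three numbers in hand, though neither neighbour separates from it beyond the scatter: compound 3 `CN1CCN(c2nc3cc([N+](=O)[O-])ccc3nc2NCc2ccc(C(F)(F)F)cc2)CC1` gives 6.99 ug/mL and compound 2 `CN1CCN(CCCNc2nc3cc([N+](=O)[O-])ccc3nc2NCc2ccc(C(F)(F)F)cc2)CC1` gives 9.53 ug/mL. The step of a 1.2-fold higher number from compound 1 to compound 3 (0.09 log units; within the scatter) is the closest model for the change to compound 4 `O=[N+]([O-])c1ccc2nc(NCc3ccc(C(F)(F)F)cc3)c(N3CCNCC3)nc2c1`, since it removes the same leaving group and installs a ring that differs from the entering one only by its methyl. piperazin-1-yl in place of (3-(dimethylamino)propyl)amino on an aromatic carbon The steps of a 1.7-fold higher number from compound 1 to compound 2 (0.23 log units; within the scatter) and a 1.4-fold lower number from compound 2 to compound 3 (0.13 log units; within the scatter) likewise stay inside the scatter. With all three measured steps this small, compound 4 is expected to sit close to compound 1, giving a step of a 1.2-fold higher number from compound 1 to compound 4 (0.08 log units; within the scatter) that should not clear the scatter. In this assay compound 4 is estimated at 6.8 ug/mL, with an expected range from 3.4 ug/mL to 13.6 ug/mL. Nothing measured here tells a bare piperazin-1-yl apart from its methylated form.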

Compound 4, half-maximal inhibitory concentration: 9.61 ug/mL
Compound 4: the middle estimate sits 1.4-fold (0.15 log units) below what was measured, and the stated range covers the measured number.
By their numbers in this assay, from the lowest: compounds 1, 3, 2 and 4 (each within the scatter of the next).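

On the aromatic carbon next to the ring nitrogen, piperazin-1-yl in place of (3-(dimethylamino)propyl)amino gives a 1.7-fold higher number from compound 1 to compound 4 (0.23 log units; within the scatter) in this assay, so a bare ring at this position does not separate from the open chain. Hydrogen in place of the ring methyl gives a 1.4-fold higher number from compound 3 to compound 4 (0.14 log units; within the scatter), and the comparison with the longer piperazinyl chain gives a 1.0-fold higher number from compound 2 to compound 4 (0.00 log units; within the scatter), which leaves all four compounds within the scatter of one another and the methylated and bare rings not told apart. No measurement in hand offers an explanation for these small steps.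

From the compounds shown here alone, whether a benzyl or acetyl group on the free piperazine nitrogen would clear the scatter stays open. So does the outcome for morpholin-4-yl, which has oxygen in place of that nitrogen.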